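This account rests on a few compounds, and the source may have more. Where it says the series, first, only, none or still open, it means among the compounds named here.

Compound 3 `COc1ccccc1/C=C(\C(=O)c1ccc(Cl)cc1)S(=O)(=O)Cc1ccc(C)cc1` gives 10000 nM in a functional assay on DU-145 cells (Homo sapiens) for inhibition, read by trypan blue exclusion, with a stated time of 96 h (a lower number here means a stronger inhibitor of growth, a higher number a weaker inhibitor of growth), level with compound 2 `Cc1ccc(CS(=O)(=O)/C(=C/c2cc(C)cc(C)c2)C(=O)c2ccc(Cl)cc2)cc1` at 10000 nM; together they sit highest among the three measured compounds, while compound 1 `Cc1ccc(CS(=O)(=O)/C(=C/c2cc(C)ccc2C)C(=O)c2ccc(Cl)cc2)cc1` gives 1000 nM. Compound 4 `Cc1ccc(CS(=O)(=O)/C(=C/c2ccccc2Br)C(=O)c2ccc(Cl)cc2)cc1` differs from compound 3 by bromo in place of methoxy on an aromatic carbon. Going by the values given here, no measured step tests bromo in place of methoxy. The steps of a 10-fold higher number from compound 1 to compound 3 (1.00 log units; beyond the scatter) and a 10-fold higher number from compound 1 to compound 2 (1.00 log units; beyond the scatter) show that changing the groups on this ring can move the number by that much, whereas no change at the digits printed from compound 2 to compound 3 (within the scatter) shows two different rings giving the same number. Compound 4 is therefore expected to show a small step, a 2.0-fold lower number from compound 3 to compound 4 (0.30 log units; within the scatter), not clearly beyond the scatter. Compound 4 is estimated at 5000 nM, within a range from 1000 nM to 20000 nM.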

Compound 4, concentration for 50% growth inhibition: 25000 nM
Beside the measured number, compound 4's estimate is 5.0-fold (0.70 log units) below it; the whole stated range lies below it.
By their numbers in this assay, from the lowest: compound 1; then compounds 2 and 3 (each within the scatter of the next); then compound 4.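

In this assay, bromo in place of methoxy gives a 2.5-fold higher number from compound 3 to compound 4 (0.40 log units; beyond the scatter) and so shows that swapping this one group on an aromatic carbon, with the rest of the molecule unchanged, can move the number beyond the scatter. The 2-bromophenyl ring also gives a 2.5-fold higher number from compound 2 to compound 4 (0.40 log units; beyond the scatter) and a 25-fold higher number from compound 1 to compound 4 (1.40 log units; beyond the scatter) and leaves compound 4 as the weakest inhibitor of growth of the four. Nothing available explains why the bromo compound gives the higher number. Still open, as far as these compounds go, is what an amine or a carboxylic acid on this same aromatic carbon would give.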